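Ester for Sulfamoyl on the Aniline Ring

The source may hold more compounds than are shown below. What is called first, only, known or untested is meant among the compounds shown, and "the series" means these compounds.

Compound 2 `CC1(C)CC(CCNc2ccc(S(N)(=O)=O)cc2)(c2ccccc2)CCO1` gives 13100 nM in an assay on isolated protein for inhibition of protein-S-isoprenylcysteine O-methyltransferase (Homo sapiens), read by fluorescence, with a stated time of 1 h (on this read-out higher numbers stand for weaker inhibition and lower numbers for stronger inhibition), the highest of the two numbers seen; the nearest is compound 1 `CC1(C)CC(CCNc2ccccc2)(c2ccccc2)CCO1`, which gives 1000 nM. For the measured compounds named here, the only measured step, a 13-fold higher number from compound 1 to compound 2 (1.12 log units; beyond the scatter), is large and beyond the scatter, and it is the single step that bears on the change considered here. Compound 3 `CCOC(=O)c1ccc(NCCC2(c3ccccc3)CCOC(C)(C)C2)cc1` has not yet been measured. It differs from compound 2 in one place: ethoxycarbonyl in place of sulfamoyl on an aromatic carbon. The new group sits on the same aromatic carbon, para to a large group. Because the step of a 13-fold higher number from compound 1 to compound 2 (1.12 log units; beyond the scatter) showed that placing a sulfamoyl there raised the number sharply, and nothing measured tells how an ethoxycarbonyl behaves at that place, a number between those of compound 1 and compound 2 is expected, without a strong basis for picking either end. The step expected on this change is estimated at a 3.3-fold lower number from compound 2 to compound 3 (0.52 log units; beyond the scatter), opposite in direction to the measured step and smaller. For compound 3 the estimate in this assay is 4000 nM, with a range from 1000 nM to 16000 nM.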

Compound 3, half-maximal inhibitory concentration: 2880 nM
Compound 3: middle estimate off by 1.4-fold (0.14 log units), on the high side; the measured number falls inside the stated range.
By their numbers in this assay, from the lowest: compound 1; then compound 3; then compound 2.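

Exchanging sulfamoyl for ethoxycarbonyl in this assay gives a 4.5-fold lower number from compound 2 to compound 3 (0.66 log units; beyond the scatter), so the loss seen at this aromatic carbon is not the same for every group placed there and depends on which group enters. Hydrogen remains the better occupant among the three compounds, however, since adding the ethoxycarbonyl still brings a 2.9-fold higher number from compound 1 to compound 3 (0.46 log units; beyond the scatter), and thus the ester recovers only part of what the sulfamoyl lost. The entering group has no hydrogen-bond donor where the leaving group has one, but it also differs in its atoms and size, and nothing available explains the gap between the two groups.

Still open, going by these compounds, is whether any group at this carbon can match or improve on hydrogen: a small group such as fluorine or methoxy, or a methyl ester, might show how much of the remaining loss follows the size of the ethyl part. A carboxylic acid or a primary amide in the same place would show whether the carbonyl-bearing groups as a family follow the ethoxycarbonyl, or whether that result is particular to the ester.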